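The source may hold more compounds than are shown below. What is called first, only, known or untested is meant among the compounds shown, and "the series" means these compounds.

Measured compounds:
- compound 1, `O=C(Nc1ccc(Cl)cc1)NS(=O)(=O)c1cccs1`: 16%
- compound 2, `CC(C)c1ccc(S(=O)(=O)NC(=O)Nc2ccc(Cl)cc2)s1`: 42%

In a functional assay on the whole organism (6C3HED cells, Mus musculus) for inhibition, at a dose of 150 mg/kg by the oral route (on this read-out lower numbers stand for less inhibition and higher numbers for more inhibition at the one dose given (going by the name of the read-out)), compound 1 gives 16%, the lowest of the two numbers shown; its nearest neighbour, compound 2, gives 42%. The unmeasured compound 3, `Cc1ccsc1S(=O)(=O)NC(=O)Nc1ccc(Cl)cc1`, differs from compound 1 in one place: methyl in place of hydrogen on an aromatic carbon. Among the compounds with values here, only one measured step bears on this change. Going a number 26 percentage points higher from compound 1 to compound 2 (beyond the scatter), the one other step in which a small carbon group replaces a hydrogen on the five-membered ring, gives a modest rise beyond the scatter. Methyl is a smaller group than isopropyl and sits at a different place on the ring, so that step is only a loose guide. A rise of similar direction but uncertain size is therefore expected, a number 11 percentage points higher from compound 1 to compound 3 (beyond the scatter), for compound 3. The estimated value for compound 3 in this assay is 27%, with a range from 5% to 50%.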

Compound 3, a percentage reported as inhibition, in the whole organism at one dose (the size of the read-out at that dose, not a potency): 17%
Compound 3: middle estimate off by 10 percentage points, on the high side; measured number inside the range.
By their numbers in this assay, from the lowest: compounds 1 and 3 (each within the scatter of the next); then compound 2.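

In this assay, methyl in place of hydrogen at this position, next to the ring atom that bears a large group, gives a number 1 percentage points higher from compound 1 to compound 3 (within the scatter) and so leaves compound 1 and compound 3 indistinguishable. A carbon group on this ring therefore does not always bring a rise like the one with isopropyl, which gives a number 26 percentage points higher from compound 1 to compound 2 (beyond the scatter) in the same test. No measurement on these compounds explains why methyl at this position leaves the number unchanged.

Still open, on these data alone, is whether a larger group at this same position, such as ethyl or a longer chain, would move the number beyond the scatter. Also open, as far as these compounds go, is whether an amine or a carboxylic acid there would raise or lower it.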